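Benzoxazole sulfonamide series: cytotoxicity notes

This account rests on a few compounds, and the source may have more. Where it says the series, first, only, none or still open, it means among the compounds named here.

Measured so far:
compound 1, `O=S(=O)(Nc1ccc(-c2nc3cc(NS(=O)(=O)c4ccc(C(F)(F)F)cc4)ccc3o2)cc1)c1ccc(C(F)(F)F)cc1`, 29000 nM
compound 2, `COc1ccc(S(=O)(=O)Nc2ccc3oc(-c4ccc(NC(=O)c5ccc(Cl)s5)cc4)nc3c2)cc1`, 15000 nM

Both compounds were tested in an ADME assay on HEK293 cells (Homo sapiens) for cytotoxicity, read by resazurin assay, with a stated time of 48 h; a higher number here means that more compound is tolerated, a lower number that less compound is tolerated. Within the data shown here, compound 2 gives 15000 nM and compound 1 gives 29000 nM; the two numbers lie within the scatter of each other, so nothing separates them and no step between measured compounds is available.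

Compound 3, `COc1ccc(S(=O)(=O)Nc2ccc3oc(-c4ccc(NC(=O)c5cccc(C)c5[N+](=O)[O-])cc4)nc3c2)cc1`, awaits measurement in this assay. Against compound 2 it carries one change:

3-methyl-2-nitrophenyl in place of 5-chlorothiophen-2-yl on a carbonyl carbon

Among the measured compounds shown here, no measured pair shows what such an amide-side replacement does in this assay, and the two numbers in hand agree with each other. On that basis the step of no change at the digits printed from compound 2 to compound 3 (within the scatter) is expected to be small, without a clear direction, and to stay within the scatter. Compound 3 is therefore estimated at 15000 nM, with a range from 6000 nM to 40000 nM.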

Compound 3, half-maximal cytotoxic concentration: 12000 nM
For compound 3 the middle estimate is 1.3-fold (0.10 log units) above the measured one, and the stated range covers the measured number.
By their numbers in this assay, from the lowest: compounds 3, 2 and 1 (each within the scatter of the next, the first and the last beyond it).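

In this assay the amide side now has its first direct reading, with a 1.3-fold lower number from compound 2 to compound 3 (0.10 log units; within the scatter) on exchanging 5-chlorothiophen-2-yl for 3-methyl-2-nitrophenyl on the carbonyl carbon. In this single pair, a five-membered aromatic ring carrying sulfur and chlorine and a larger six-membered carbon ring carrying methyl and nitro are not separated by this read-out, so this position accepts at least this one replacement without a step beyond the scatter. Nothing at hand bears on the reason for this result.

Still open, from the compounds shown here alone, is whether a group of a different kind on the carbonyl carbon, such as a saturated cyclohexyl ring, a primary amine or a carboxylic acid on the aromatic ring, would give a number beyond the scatter. Also open, going by these compounds, is whether the same reading holds with a different sulfonamide partner on the shared core.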